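The source may report more compounds than this note shows. Statements on the series, on what has been measured and on what is new or still open speak of the compounds shown alone.

Measured compounds, all in a functional assay on MCF7 cells (Homo sapiens) for cytotoxicity, read by CellTiter-Glo, with a stated time of 5 days; on this read-out lower numbers stand for stronger inhibition and higher numbers for weaker inhibition:

Compound 1 `CC/C(=C(/c1ccc(/C=C/C(=O)O)cc1)c1ccc(O)nc1)c1ccccc1` gives "not determined" (no result reported)
Compound 2 `CC/C(=C(/c1ccc(/C=C/C(=O)O)cc1)c1ccc2[nH]ncc2c1)c1ccccc1` gives 6 nM
Compound 3 `CC/C(=C(\c1ccc2[nH]ncc2c1)c1ccc(/C=C/C(=O)O)cc1C)c1ccccc1` gives 36 nM

Compound 2 holds the lower of the two numbers available, with compound 3 as its nearest neighbour and compound 1 offering no number for comparison. Attention now turns to compound 4 `CC/C(=C(/c1ccc(/C=C/C(=O)O)cc1)c1ccc2[nH]ncc2c1)c1ccccc1C`, which has not yet been measured. Its difference from compound 2 is methyl in place of hydrogen on an aromatic carbon and amounts to methyl in place of hydrogen on an aromatic carbon, ortho to a large group, or phenyl to 2-methylphenyl.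

Among the compounds with values here, the only measured step of this kind is a 6.0-fold higher number from compound 2 to compound 3 (0.78 log units; beyond the scatter) and it lies at a different place in the molecule. That single step therefore suggests a direction and a rough size, but it cannot fix the outcome for the new place. In this assay a higher number is expected, with a rise probably smaller than the measured one and possibly close to the scatter. The estimated change is a 2.3-fold higher number from compound 2 to compound 4 (0.37 log units; beyond the scatter) as the expected outcome. For compound 4 the estimated value is 14 nM with an expected range from 4 nM to 50 nM in repeat measurements.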

Compound 4, half-maximal inhibitory concentration: 4 nM
The estimate for compound 4 lay 3.5-fold (0.54 log units) above the measured number; the measured number falls inside the stated range.
By their numbers in this assay, from the lowest: compounds 4 and 2 (each within the scatter of the next); then compound 3.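

In this assay, phenyl to 2-methylphenyl gives a step that lies within the scatter (a 1.5-fold lower number from compound 2 to compound 4 (0.18 log units; within the scatter)), so this position accepts a methyl with no readable change in the number. Within the data shown here, the only earlier methyl step lay beyond the scatter at a different place in the molecule (a 6.0-fold higher number from compound 2 to compound 3 (0.78 log units; beyond the scatter)), and the two steps together show that the same exchange of hydrogen for methyl does not give one outcome across the molecule. This contrast rests on just these two steps, and no measurement bears on what lies behind either of them.

The compounds shown leave open whether this position would accept anything other than methyl, such as a chlorine atom, a methoxy group, an amine or a longer chain like ethyl, and whether methyl on the other carbons of the same ring would give a similar result. Among these compounds, they also leave open how a compound carrying both methyl groups would read, since each methyl has been seen only on its own.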